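A few compounds are considered here, and "the series" means these few. Any claim that something is new, unique, unknown or untested is made for them only; others in the source may bear on it.

Compound 1 `CCCS(=O)(=O)Nc1ccc(F)c(C(=O)c2n[nH]c3ncc(-c4cccc(N)c4)cc23)c1F`: 1.6%
Compound 2 `CCCS(=O)(=O)Nc1ccc(F)c(C(=O)c2n[nH]c3ncc(-c4cccc(C(F)(F)F)c4)cc23)c1F`: 57%

In an assay for binding affinity to dual specificity mitogen-activated protein kinase kinase 4 (Homo sapiens), read by KINOMEscan, tested at 100 nM (a higher number here means a weaker effect of the compound at the concentration tested, a lower number a stronger effect), compound 1 gives 1.6%, the lower of the two numbers, while compound 2 gives 57%. Among the measured compounds shown here, the single measured step, a number 55.4 percentage points higher from compound 1 to compound 2 (beyond the scatter), is a large rise when trifluoromethyl takes the place of amino on an aromatic carbon. Compound 3 `CCCS(=O)(=O)Nc1ccc(F)c(C(=O)c2n[nH]c3ncc(-c4ccc(S(=O)(=O)NCC)cc4)cc23)c1F` also loses that amino group: 4-(ethylsulfamoyl)phenyl in place of 3-aminophenyl on an aromatic carbon. For the measured compounds named here, that one step is the only guide, and the entering group is not trifluoromethyl, so a rise is expected but its size is uncertain. Compound 3 is expected to give about 35%, within 5% to 80%. This estimate amounts to an expected step of a number 33.4 percentage points higher from compound 1 to compound 3 (beyond the scatter), likely beyond the scatter.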

Compound 3, a percentage reported as activity, at one concentration (the size of the read-out at that concentration, not a potency): 3%
Beside the measured number, compound 3's estimate is 32 percentage points above it; measured number below the stated range.
By their numbers in this assay, from the lowest: compounds 1 and 3 (each within the scatter of the next); then compound 2.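

In this assay, the low number of compound 1 does not depend on keeping 3-aminophenyl at this position: a number 1.4 percentage points higher from compound 1 to compound 3 (within the scatter). The rise seen with trifluoromethyl therefore does not apply to every replacement of the amino group, as shown by a number 54 percentage points lower from compound 2 to compound 3 (beyond the scatter). Nothing available here accounts for the gap between these two replacements.

Going by these compounds, it remains open whether the ethylsulfamoyl group itself or its different place on the phenyl ring matters more. On these data alone, how a carboxylic acid, or a longer chain in place of ethyl, would read here is also open.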